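Quinazolinyl-thioacetamide anilides: first numbers and a forecast

The compounds below may be only part of what the source reports. "The series", "measured", "known", "first", "only" and "open" are said of these compounds alone.

Measured so far:
compound 1, `O=C(CSc1nc(Nc2ccccc2)c2ccccc2n1)Nc1cccc(Cl)c1` — 8460 nM
compound 2, `O=C(CSc1nc(Nc2ccccc2)c2ccccc2n1)Nc1ccc(F)c(Cl)c1` — 9390 nM
compound 3, `C=CC(=O)Nc1cccc(NC(=O)CSc2nc(Nc3ccccc3Br)c3ccccc3n2)c1` — 19300 nM

The three measured compounds share one core and differ in the two aryl groups. Among the measured compounds shown here, in a functional assay on NCI-H1975 cells (Homo sapiens) for inhibition, read by MTT assay, with a stated time of 72 h (on this read-out lower numbers stand for stronger inhibition and higher numbers for weaker inhibition), compound 1 gives 8460 nM and compound 2 gives 9390 nM; the single one-place step, a 1.1-fold higher number from compound 1 to compound 2 (0.05 log units; within the scatter), lies within the scatter. Compound 3 stands at the highest number of the three in this assay, beyond the scatter from both compound 1 and compound 2, but it differs from them in two places at once, so no single cause can be read from it.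

Compound 4, `C=CC(=O)Nc1cccc(NC(=O)CSc2nc(Nc3ccc(C(F)(F)F)cc3)c3ccccc3n2)c1`, has not yet been measured. It differs from compound 3 in one place: 4-(trifluoromethyl)phenyl in place of 2-bromophenyl on a nitrogen on an aromatic ring. For the measured compounds named here, no measured step touches the aryl group on this nitrogen; the only measured step concerns the other aryl group and was within the scatter. There is therefore no basis to expect a step beyond the scatter in this assay in either direction, and the expectation for compound 4 rests on the number of compound 3, 19300 nM, with a wide range. Compound 4 is estimated at 18000 nM (range 7000 nM to 45000 nM), which means an expected step of a 1.1-fold lower number from compound 3 to compound 4 (0.03 log units; within the scatter).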

Compound 4, half-maximal inhibitory concentration: 12900 nM
Compound 4: the middle estimate sits 1.4-fold (0.14 log units) above what was measured, within the range that was stated.
By their numbers in this assay, from the lowest: compounds 1, 2, 4 and 3 (each within the scatter of the next, the first and the last beyond it).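

Working notes: this is the first one-place step at the aryl group on a nitrogen on an aromatic ring. In this assay, 4-(trifluoromethyl)phenyl in place of 2-bromophenyl gives a 1.5-fold lower number from compound 3 to compound 4 (0.17 log units; within the scatter), so the two groups are not separated at this position, although the group that enters has 10 heavy atoms and the one that leaves has 7, and they carry different substituents on the ring. No measurement shown bears on the reason for this result or on how these two aryl groups behave in the cells.

Among the compounds shown here, this step covers only two aryl groups, both with one six-membered aromatic ring of carbon only and 0 hydrogen-bond donors and acceptors, so it remains open whether an amine or a carboxylic acid on that ring, or a longer alkyl chain in place of the ring, would give a step beyond the scatter. Also open, going by these compounds, is whether the same exchange on the nitrogen would read the same way with the 3-chlorophenyl amide of compound 1 in place of the other aryl group of compound 3.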